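Methoxy shift on the benzylthio arm of the propargylamine series

The source may report more compounds than this note shows. Statements on the series, on what has been measured and on what is new or still open speak of the compounds shown alone.

Measured compounds:
compound 1 `C#CCNC1CCc2c(SCc3cccc(OC)c3)cccc21` 1520 nM
compound 2 `C#CCNC1CCc2c(SCc3cccc(Cl)c3)cccc21` 1090 nM
compound 3 `C#CCNC1CCc2c(SCc3ccccc3)cccc21` "not active" (no number reported)

Among the compounds with values here, in an ADME assay on isolated protein for inhibition of Amine oxidase [flavin-containing] B (Homo sapiens) (a higher number here means a weaker inhibitor, a lower number a stronger inhibitor), compound 1 gives 1520 nM and compound 2 gives 1090 nM; the step of a 1.4-fold lower number from compound 1 to compound 2 (0.14 log units; within the scatter) is the only one between two numbered compounds. Compound 3 carries the unsubstituted benzyl arm and in this assay compound 3 gives "not active" (no number reported): it was reported without activity and without a number, so its standing on the numbers shown cannot be fixed.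

Compound 4 `C#CCNC1CCc2c(SCc3ccc(OC)cc3)cccc21` is not yet measured. It differs from compound 3 by methoxy in place of hydrogen on an aromatic carbon. Within the data shown here, no measured step bears directly on this change; the step from compound 1 to compound 2 concerns an exchange at a different place and was within the scatter, so it offers no direction. What the data show is that compounds 1 and 2, each carrying one group on the benzyl ring, reach the low-micromolar range where compound 3 gives no number. On that basis compound 4 is expected to gain a measurable number, though with wide uncertainty; the estimate for compound 4 in this assay is 3000 nM, between 800 nM and 15000 nM.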

Compound 4, half-maximal inhibitory concentration: 3960 nM
Beside the measured number, compound 4's estimate is 1.3-fold (0.12 log units) below it; the measured number falls inside the stated range.
By their numbers in this assay, from the lowest: compounds 2 and 1 (each within the scatter of the next); then compound 4.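

In this assay, within the data shown here, compound 4 gives 3960 nM while compound 3 has no number, so no step from compound 3 to compound 4 can be read. No supporting data bear on this result. The compounds shown leave open how far methoxy in place of hydrogen shifts the number in this assay.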